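The compounds below may be only part of what the source reports. "The series", "measured", "known", "first", "only" and "open" are said of these compounds alone.

Measured so far:
Compound 1, `CC[C@H](C)[C@H](NC(=O)CN(c1nc(Cl)nc2[nH]cnc12)C1CC1)C(=O)OCc1ccccc1`, in a functional assay on the whole organism (Tail, strain ICR) with Mus musculus as the target, in the tail flick test, with a stated time of 90 min, at a dose of 25 umol/kg by the oral route (on this read-out higher numbers stand for a stronger effect at the one dose given and lower numbers for a weaker effect), gives 36.3%.
Compound 2, `NC(=O)CC[C@H](NC(=O)CN(c1ncnc2c1ncn2C1CCCCO1)C1CC1)C(=O)OCc1ccccc1`, in this assay gives 37.8%.

For the measured compounds named here, only two compounds have numbers, and compound 1 and compound 2 sit within the scatter of each other, so neither can be called the stronger or the weaker. Going by the values given here, no step between measured compounds that differ in one place is available, so the study gives no gauge of how a change on the side chain moves the read-out.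

Compound 3, `C[C@@H](O)[C@H](NC(=O)CN(c1nc(Cl)nc2[nH]cnc12)C1CC1)C(=O)OCc1ccccc1`, is not yet measured. It differs from compound 1 by hydroxy in place of ethyl on a saturated chain carbon bound to two saturated chain carbons. With nothing measured that bears on such a change, compound 3 is expected to stay close to compound 1, with the step of a number 3.3 percentage points lower from compound 1 to compound 3 (within the scatter) estimated to be none beyond the scatter. Compound 3 is therefore estimated at 33%, within a range from 15% to 55%.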

Compound 3, a percentage reported as activity, at one dose (the size of the read-out at that dose, not a potency): 29.9%
For compound 3 the middle estimate is 3.1 percentage points above the measured one, and the stated range covers the measured number.
By their numbers in this assay, from the lowest: compounds 3, 1 and 2 (each within the scatter of the next).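

The pair of compound 1 and compound 3 gives the study its first gauge at this position: hydroxy in place of ethyl on a saturated chain carbon bound to two saturated chain carbons gives a number 6.4 percentage points lower from compound 1 to compound 3 (within the scatter) in this assay at the one dose given. The sec-butyl to 1-hydroxyethyl change therefore cannot be told apart from the usual scatter of this read-out, although it brings in a hydrogen-bond donor and a hydrogen-bond acceptor that the ethyl lacks. Nothing shown here accounts for this result.

As far as these compounds go, whether an amine, a carboxylic acid or a longer chain at this place would produce a step beyond the scatter remains open. So does whether the same change would read alike on a core other than that of compound 1.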